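A Methyl Removed, Starting From a Limit

The source may report more compounds than this note shows. Statements on the series, on what has been measured and on what is new or still open speak of the compounds shown alone.

Compound 1 `COc1ccc(-c2nc3cc(NC(=O)[C@H](C)Oc4ccccc4CN)ccc3o2)cc1` gives > 5000 nM in an assay on isolated protein for inhibition of GMP reductase 2 (Homo sapiens), read by spectrophotometry (a lower number here means a stronger inhibitor, a higher number a weaker inhibitor), a limit of the assay.
Compound 2 `COc1ccc(-c2nc3cc(NC(=O)[C@H](C)Oc4cccc(Cl)c4Cl)ccc3o2)cc1` gives > 5000 nM in this assay, a limit of the assay.

Compound 2 stands only at a limit of the assay in this assay, with no number of its own. Going by the values given here, the single measured step, a step that the two limits leave unreadable from compound 1 to compound 2, cannot be read because of the limit of > 5000 nM in this assay, at which 2 of the 2 values shown sit. Compound 3 `C[C@H](Oc1cccc(Cl)c1Cl)C(=O)Nc1ccc2oc(-c3ccc(O)cc3)nc2c1` differs from compound 2 by hydrogen in place of methyl on an oxygen on an aromatic ring. Among the compounds with values here, no measured step touches this change, so no direction beyond the scatter can be expected. Compound 3 is therefore expected to give 8000 nM in this assay, within 2000 nM to 50000 nM, most likely again only a limit. The step that the limit leaves unreadable from compound 2 to compound 3 is estimated to be small.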

Compound 3, inhibition constant: > 5000 nM
Compound 3: no number, only a limit; the forecaster's own chance of this, stated with the estimate: 75%; the middle value does not contradict the limit.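

No step can be read from compound 2 to compound 3, because both stand only at a limit of the assay: the limit of > 5000 nM in this assay, at which 3 of the 3 values shown sit.

Going by these compounds, how strongly any of the three compounds acts in this assay, and whether methoxy to hydroxy matters there, stays open.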